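A few compounds are considered here, and "the series" means these few. Any claim that something is new, unique, unknown or untested is made for them only; others in the source may bear on it.

Compound 3 `Cc1c(-c2csc(/N=C3\S/C(=C\c4ccccc4)C(=O)N3c3ccccc3)n2)c(=O)n(-c2ccccc2)n1C` carries a benzylidene on the shared core beside the thiazole-linked pyrazolone. In a functional assay on MCF7 cells (Homo sapiens) for cytotoxicity, read by sulforhodamine B assay, with a stated time of 72 h (on this read-out higher numbers stand for weaker inhibition and lower numbers for stronger inhibition), compound 3 gives > 100000 nM, which is a limit of the assay and not a number. It is one of the values described by the limit of > 100000 nM in this assay, at which 2 of the 3 values shown sit. Compound 4 `Cc1ccc(/C=C2\S/C(=N\c3nc(-c4c(C)n(C)n(-c5ccccc5)c4=O)cs3)N(c3ccccc3)C2=O)cc1` differs from it by methyl in place of hydrogen on an aromatic carbon. For the measured compounds named here, no measured step matches this change. The nearest comparison is the pair compound 1 `CC(=O)c1nn(-c2ccc(Cl)cc2)/c(=N/c2nc(-c3c(C)n(C)n(-c4ccccc4)c3=O)cs2)s1` and compound 2 `CC(=O)c1nn(-c2ccc(C)cc2)/c(=N/c2nc(-c3c(C)n(C)n(-c4ccccc4)c3=O)cs2)s1`, which differ by methyl in place of chloro on an aromatic carbon. In this assay compound 1 gives > 100000 nM, again a limit and not a number. Compound 2 gives 56800 nM in this assay. The step of an at least 1.7-fold lower number from compound 1 to compound 2 (0.24 log units; that floor lies within the scatter) starts from a limit and lies within the scatter, so it shows only that a methyl on that ring did not push the number upward. Compound 4 is therefore expected to give about 100000 nM, with a range from 30000 nM to 300000 nM. The step this estimate means, a number no higher from compound 3 to compound 4 (the limit leaves the size open), is expected to stay within the scatter, and a limit rather than a number is the likelier outcome.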

Compound 4, half-maximal inhibitory concentration: > 100000 nM
Compound 4: only a limit was reported; the forecaster's own chance of this, stated with the estimate: 65%; the middle value sits exactly at the limit.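

In this assay, for the compounds shown here, compound 3 and compound 4 both end at a limit and not at a number, so no step between them can be read: the limit of > 100000 nM in this assay, at which 3 of the 4 values shown sit. The compounds shown leave open whether phenyl to 4-methylphenyl changes the cytotoxicity of compound 3 at all.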